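The source may report more compounds than this note shows. Statements on the series, on what has been measured and on what is new or still open speak of the compounds shown alone.

Measured compounds:
Compound 1 `CCCc1ccncc1C#Cc1cc(Cl)ccc1OCC(=O)O` gives 4.3 nM
Compound 2 `N#Cc1ccc(OCC(=O)O)c(C#Cc2ccccc2Cl)c1` gives 24 nM
Compound 3 `Cn1ccnc1C#Cc1cc(Cl)ccc1OCC(=O)O` gives 1470 nM

These three numbers come from an assay on CHO cells for displacement of a labelled ligand from prostaglandin D2 receptor 2 (Homo sapiens), read by scintillation counting; on this read-out higher numbers stand for weaker inhibition and lower numbers for stronger inhibition. Compound 1 stands at the lowest of them, the strongest inhibition shown; compound 2 sits at a higher number beyond the scatter, and compound 3 at a far higher number, also beyond the scatter. Compound 4 `CC(C)Cc1ccncc1C#Cc1cc(Cl)ccc1OCC(=O)O` is not yet measured. It differs from compound 1 by methyl in place of hydrogen on a saturated chain carbon bound to two saturated chain carbons; cut one bond further out, the same difference reads propyl to isobutyl. Among the compounds with values here, no pair of measured compounds shows a step of this kind. A small step in this assay is therefore expected, toward a somewhat higher number or none beyond the scatter. Compound 4 is estimated at 7 nM, between 2.5 nM and 25 nM, a step of a 1.6-fold higher number from compound 1 to compound 4 (0.21 log units; within the scatter) expected.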

Compound 4, inhibition constant: 4.9 nM
Compound 4: the middle estimate sits 1.4-fold (0.15 log units) above what was measured; the range from low to high includes it.
By their numbers in this assay, from the lowest: compounds 1 and 4 (each within the scatter of the next); then compound 2; then compound 3.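

In this assay, the change from propyl to isobutyl gives a 1.1-fold higher number from compound 1 to compound 4 (0.06 log units; within the scatter), so the two compounds cannot be told apart on this read-out. Within the data shown here, this is the first evidence about this saturated chain carbon: here, the shared core accepts a methyl in place of hydrogen without a difference beyond the scatter. Nothing measured here says why.

This single step shows only a branch of one methyl on one core. Going by these compounds, whether a longer chain, a hydroxyl group or an amine on this chain would read alike remains open.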